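The compounds below may be only part of what the source reports. "The series", "measured", "known", "first", "only" and "open" are said of these compounds alone.

Measured compounds:
compound 1 `O=S(=O)(/C=C/c1ccc(F)cc1)Cc1ccc(Nc2ncnc3ccccc23)cc1` — 10 nM
compound 2 `O=S(=O)(/C=C/c1ccc(Cl)cc1)Cc1ccc(Nc2ncnc3ccccc23)cc1` — > 100000 nM
compound 3 `O=S(=O)(/C=C/c1ccc(F)cc1F)Cc1ccc(Nc2ncnc3ccccc23)cc1` — 31000 nM

In a functional assay on ACHN cells (Homo sapiens) (a higher number here means a weaker inhibitor of growth, a lower number a stronger inhibitor of growth), compound 1 gives 10 nM. For compound 2 the reported value is a limit of the assay (the limit of > 100000 nM in this assay, at which 1 of the 3 values shown sits). Compound 3 gives 31000 nM in this assay. The step of an at least 10000-fold higher number from compound 1 to compound 2 (4.00 log units; beyond the scatter) rests on the change (chloro in place of fluoro on an aromatic carbon). The cores of compound 1 and compound 3 differ by fluoro in place of hydrogen on an aromatic carbon, giving a 3100-fold higher number from compound 1 to compound 3 (3.49 log units; beyond the scatter). Between them, an at least 3.2-fold lower number from compound 2 to compound 3 (0.50 log units; beyond the scatter).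

Compound 4 `O=S(=O)(/C=C/c1ccc(F)cc1Cl)Cc1ccc(Nc2ncnc3ccccc23)cc1` is not yet measured. It differs from compound 3 by chloro in place of fluoro on an aromatic carbon, the same kind of change as from compound 1 to compound 2, though here the place is ortho to a large group and meta to a fluoro group rather than para to a large group. Given the step of an at least 10000-fold higher number from compound 1 to compound 2 (4.00 log units; beyond the scatter), a weakening step is expected here too, and compound 4 is estimated at 100000 nM in this assay, spanning 30000 nM to 300000 nM, a step of a 3.2-fold higher number from compound 3 to compound 4 (0.51 log units; beyond the scatter) that is expected to end at the assay limit.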

Compound 4, concentration for 50% growth inhibition: 73000 nM
Compound 4: the middle estimate sits 1.4-fold (0.14 log units) above what was measured, and the stated range covers the measured number.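

In this assay, chloro in place of fluoro on an aromatic carbon does not carry over in size from one core to another: the same change on two cores in this assay, an at least 10000-fold higher number (4.00 log units; beyond the scatter) from compound 1 to compound 2 and a 2.4-fold higher number (0.37 log units; beyond the scatter) from compound 3 to compound 4, at least 4200-fold (3.62 log units) apart, beyond the scatter of two such steps.
Compound 2 stands at a limit of the assay, and its step from compound 1 gives only a floor: the limit of > 100000 nM in this assay, at which 1 of the 4 values shown sits.
Among these compounds, the step that rests on this limit is likewise only a floor, an at least 1.3-fold lower number from compound 2 to compound 4 (0.13 log units; that floor lies within the scatter), and it gives no order for the pair.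
Both readable comparisons point upward, with a 2.4-fold higher number from compound 3 to compound 4 (0.37 log units; beyond the scatter) and a 7300-fold higher number from compound 1 to compound 4 (3.86 log units; beyond the scatter), but these few pairs, with the change at different places on the ring, do not show why the size differs or what it would be on a further core.

Open, from the compounds shown here alone, is whether a methoxy group or an amine in place of the chloro of compound 4 would stay in the range of compound 3. Also open, going by these compounds, is how a longer chain in place of the ethenyl link would affect these steps.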